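This account rests on a few compounds, and the source may have more. Where it says the series, first, only, none or still open, it means among the compounds named here.

Values in a functional assay on OVCAR-3 cells (Homo sapiens) for cytotoxicity, read by sulforhodamine B assay; on this read-out higher numbers stand for lower toxicity in this test and lower numbers for higher toxicity in this test:
- compound 1 `COc1ccc(/C=N\NC(=S)NC(C)(C)CCC[C@](C)(O)[C@@H]2CC=C(C)CC2)cc1`: 46200 nM
- compound 2 `CC1=CC[C@@H]([C@@](C)(O)CCCC(C)(C)NC(=S)N/N=C\c2ccccc2[N+](=O)[O-])CC1`: 41900 nM
- compound 3 `CC1=CC[C@@H]([C@@](C)(O)CCCC(C)(C)NC(=S)N/N=C\c2cccc([N+](=O)[O-])c2)CC1`: > 100000 nM (a limit of the assay, not a number)

Compound 3 has the highest reading of the three, which here means the lowest toxicity. Both steps towards it lie beyond the scatter: an at least 2.1-fold higher number from compound 1 to compound 3 (0.33 log units; beyond the scatter) and an at least 2.3-fold higher number from compound 2 to compound 3 (0.37 log units; beyond the scatter).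

Compound 4 `CC1=CC[C@@H]([C@@](C)(O)CCCC(C)(C)NC(=S)N/N=C\c2cccc(Cl)c2)CC1` differs from compound 3 in one place, with chloro in place of nitro on an aromatic carbon, meta to a large group: chloro in place of nitro on an aromatic carbon. Going by the values given here, no measured step makes this exact swap, so the nearest guides are the other changes to the same aromatic ring. The two compounds without the 3-nitrophenyl group both gave real numbers, and the gap between them is small: a 1.1-fold lower number from compound 1 to compound 2 (0.04 log units; within the scatter). On this thin evidence, a modest move to a lower number is expected in this assay, and the expected step is an at least 1.8-fold lower number from compound 3 to compound 4 (0.25 log units; that floor lies within the scatter). The group stays in the same place, so a reading at the limit remains possible. For compound 4 the estimated value is 55000 nM, with an expected range from 25000 nM to 100000 nM.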

Compound 4, concentration lethal to 50% of the cells: 48000 nM
The estimate for compound 4 lay 1.1-fold (0.06 log units) above the measured number; low and high end bracket the measured number.
By their numbers in this assay, from the lowest: compounds 2, 1 and 4 (each within the scatter of the next). At a limit, above all of these: compound 3.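

In this assay, the change from 3-nitrophenyl to 3-chlorophenyl gives an at least 2.0-fold lower number from compound 3 to compound 4 (0.31 log units; beyond the scatter) and shows that, at this place on the ring, the reading does not stay at the limit once nitro is replaced by chloro. The reading of compound 3 is a limit and not a number, so the full size of this step cannot be told: the limit of > 100000 nM in this assay, at which 1 of the 4 values shown sits. With chloro at this place, the readings show a 1.1-fold higher number from compound 2 to compound 4 (0.06 log units; within the scatter) and a 1.0-fold higher number from compound 1 to compound 4 (0.02 log units; within the scatter) and leave the 3-nitrophenyl compound alone at the limit among these four compounds.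

On these data alone, whether an amine or a carboxylic acid at this place would keep the reading at the limit or bring it down stays open. So does whether a nitrile here would behave like nitro or like chloro.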